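A few compounds are considered here, and "the series" means these few. Any claim that something is new, unique, unknown or untested is made for them only; others in the source may bear on it.

Of the compounds shown here, three built on one shared core have been measured in an assay on isolated protein for inhibition of high affinity nerve growth factor receptor (Homo sapiens), read by 33P incorporation; on this read-out lower numbers stand for stronger inhibition and higher numbers for weaker inhibition. Compound 1 `Nc1cc(-c2cnc3[nH]cc(-c4ccncc4)c3c2)ccc1Cl` gives 53.7 nM in this assay. Compound 2 `COc1ccc(N)cc1-c1cnc2[nH]cc(-c3ccncc3)c2c1` gives 110 nM. Compound 3 `Nc1cc(NS(=O)(=O)c2ccccc2)cc(-c2cnc3[nH]cc(-c4ccncc4)c3c2)c1` gives 9.4 nM, the lowest of the three numbers; its gap to compound 1 and its gap to compound 2 both lie beyond the usual scatter of repeated measurements, so compound 3 stands as the strongest inhibitor among the three measured compounds.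

Compound 4 `Nc1cc(NS(=O)(=O)c2ccc(F)cc2F)cc(-c2cnc3[nH]cc(-c4ccncc4)c3c2)c1` has not yet been measured. It differs from compound 3 in a single place: 2,4-difluorophenyl in place of phenyl on a sulfonyl sulfur. Everything else in the molecule, including the sulfonamide and the shared core, is unchanged.

Within the data shown here, no pair of measured compounds here shows what putting fluorine onto a phenyl ring of this kind does, so the size of the step cannot be read from the data. Because compound 3 gives 9.4 nM and the change is confined to the ring on the sulfonyl sulfur, compound 4 is expected to stay close to compound 3, with a step of a 1.2-fold lower number from compound 3 to compound 4 (0.07 log units; within the scatter) that may well fall within the scatter. The value expected for compound 4 in this assay is 8 nM, with a range from 3 nM to 25 nM.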

Compound 4, half-maximal inhibitory concentration: 2.97 nM
Estimate against measurement, compound 4: 2.7-fold (0.43 log units) above, outside the stated range (below it).
By their numbers in this assay, from the lowest: compound 4; then compound 3; then compound 1; then compound 2.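

In this assay, the ring on the sulfonyl sulfur proves to be a place where a small change registers: 2,4-difluorophenyl in place of phenyl gives a 3.2-fold lower number from compound 3 to compound 4 (0.50 log units; beyond the scatter), a modest step but one beyond the usual scatter of repeated measurements. The earlier compounds shown here could not show this, since no two of them differed in only one place, whereas this pair isolates a single change with the sulfonamide and the shared core held constant, and so shows that adding two fluorine atoms to this ring goes with stronger inhibition. No measurement at hand explains why the step occurs, so its cause remains unknown.

Going by these compounds, it remains open whether both fluorine atoms are needed or whether a phenyl ring carrying a single fluorine would give the same step, and how this ring would respond to a chlorine, a methoxy group or an amine instead. Also open, on these data alone, is what a methyl group or a longer alkyl chain on the sulfonyl sulfur would do in place of the ring.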